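This account rests on a few compounds, and the source may have more. Where it says the series, first, only, none or still open, it means among the compounds named here.

Measured compounds in a functional assay on MCF7 cells (Homo sapiens) for inhibition, read by MTT assay, with a stated time of 72 h; on this read-out lower numbers stand for stronger inhibition and higher numbers for weaker inhibition:
- compound 1, `Cc1cc(Nc2cc(-c3ccccc3)[nH]n2)n2nc(SCCCc3ccccc3)nc2n1`: 3900 nM
- compound 2, `Cc1cc(Nc2cc(-c3ccccc3)[nH]n2)n2ncnc2n1`: > 50000 nM, a limit of the assay and not a number
- compound 3, `Cc1cc(Nc2cc(-c3ccccc3)[nH]n2)n2nc(SCC3CC3)nc2n1`: > 50000 nM, a limit of the assay and not a number

Within the data shown here, compound 1 stands as the only number in this assay; the other two values sit at the limit of > 50000 nM in this assay, at which 2 of the 3 values shown sit. Taking away the (3-phenylpropyl)sulfanyl group gives an at least 12-fold higher number from compound 1 to compound 2 (1.10 log units; beyond the scatter). Putting cyclopropyl in place of phenethyl gives an at least 12-fold higher number from compound 1 to compound 3 (1.10 log units; beyond the scatter). The step from compound 2 to compound 3 is a step that the two limits leave unreadable from compound 2 to compound 3, since both values are limits.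

Compound 4, `Cc1cc(Nc2cc(-c3ccccc3)[nH]n2)n2nc(SCC3CCCCC3)nc2n1`, differs from compound 1 in this way: cyclohexyl in place of phenethyl on a saturated chain carbon bound to a sulfur. Among the measured compounds shown here, the measured step that bears on it is the one from compound 1 to compound 3, where phenethyl gave way to a saturated ring and the number ran past the limit. Compound 4 keeps a six-membered ring on the chain, but a non-aromatic one, so a weakening is expected, though of uncertain size because the step from compound 1 to compound 3 ended at a limit. The expected step is a 3.8-fold higher number from compound 1 to compound 4 (0.59 log units; beyond the scatter). Compound 4 is estimated at 15000 nM, within a range from 4000 nM to 50000 nM, with a real chance that this assay returns only a limit.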

Compound 4, half-maximal inhibitory concentration: > 50000 nM
Compound 4: no number, only a limit; the forecaster's own chance of this, stated with the estimate: 35%; middle value at least 3.3-fold (0.52 log units) away from the limit.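

In this assay compound 4 gives > 50000 nM, a limit of the assay and not a number. The step with cyclohexyl in place of phenethyl is an at least 12-fold higher number from compound 1 to compound 4 (1.10 log units; beyond the scatter), so a six-membered ring at the end of the chain is not enough to keep the measurable value of compound 1, and a larger saturated ring than the cyclopropyl of compound 3 does not restore one. Read one bond further out, this change is 3-phenylpropyl to cyclohexylmethyl, so the ring type and the chain length change together, and the steps among compounds 2, 3 and 4 cannot be read, since all three values are limits: the limit of > 50000 nM in this assay, at which 3 of the 4 values shown sit.

The compounds shown do not separate the aromatic ring from the chain length: a (3-cyclohexylpropyl)sulfanyl group would keep the chain of compound 1 with a saturated ring, and a benzylsulfanyl group would keep the aromatic ring on a shorter chain. Also open, from the compounds shown here alone, is how a longer chain, or an amine at the end of the chain, would compare with the (3-phenylpropyl)sulfanyl group of compound 1.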